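A Cyano Group Replaces Fluorine on a Benzamide Series

The compounds below may be only part of what the source reports. "The series", "measured", "known", "first", "only" and "open" are said of these compounds alone.

Of the compounds shown here, three sharing one core have been tested in a functional assay on Shh Light II cells for inhibition of Sonic hedgehog protein (Mus musculus), read by reporter gene assay, with a stated time of 48 h, in the presence of a further agent that is not named here; on this read-out lower numbers stand for stronger inhibition and higher numbers for weaker inhibition. Compound 1 `COc1cc(C(=O)Nc2ccc(Cl)c(-c3nc4ccccc4[nH]3)c2)cc(OC)c1OC` carries a trimethoxyphenyl amide, and in this assay compound 1 gives 79.8 nM. Compound 2 `O=C(Nc1ccc(Cl)c(-c2nc3ccccc3[nH]2)c1)c1ccc(F)cc1` carries a 4-fluorophenyl amide instead, and in this assay compound 2 gives 251 nM. Compound 3 `CCOc1cc(C(=O)Nc2ccc(Cl)c(-c3cc4ccccc4[nH]3)c2)cc(OC)c1OC` differs in its core and in one of its alkoxy groups, and in this assay compound 3 is reported as "not active" (no number reported) without a number.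

Among the two compounds with a number, compound 2 stands at the higher one, so it is the weaker inhibitor of the pair; the gap to compound 1 lies beyond the usual scatter of repeated measurements.

Compound 4 `N#Cc1ccc(C(=O)Nc2ccc(Cl)c(-c3nc4ccccc4[nH]3)c2)cc1` has not yet been measured. It differs from compound 2 in one place: cyano in place of fluoro on an aromatic carbon, in words, cyano in place of fluoro on an aromatic carbon, para to a large group on the amide-bearing phenyl ring.

Among the compounds with values here, no measured pair shows this exact swap, so there is no direct guide. The expectation is that the change from compound 2 to compound 4 produces a step of a 1.3-fold lower number from compound 2 to compound 4 (0.10 log units; within the scatter) that stays within the scatter. On that basis compound 4 is estimated to give 200 nM in this assay, with a range from 60 nM to 700 nM.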

Compound 4, half-maximal inhibitory concentration: 185 nM
The estimate for compound 4 lay 1.1-fold (0.03 log units) above the measured number; measured number inside the range.
By their numbers in this assay, from the lowest: compound 1; then compounds 4 and 2 (each within the scatter of the next).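

In this assay, within the data shown here, the step of a 1.4-fold lower number from compound 2 to compound 4 (0.13 log units; within the scatter) is the first reading of a change at one single place, and it stays within the usual scatter. At this position on the aromatic ring, para to a large group, 4-fluorophenyl and 4-cyanophenyl therefore cannot be told apart by this read-out, even though cyano brings a triple bond and a hydrogen-bond acceptor that fluoro lacks, so the position accepts this swap without a clear gain or loss in inhibition. Nothing measured here offers an explanation for why the two compounds read alike.

Going by these compounds, two groups that read alike say little about the position as a whole, so it remains open whether an amine, a carboxylic acid, a methoxy group or a longer alkyl chain at the same place would also stay within the scatter of compound 2, or whether a plain hydrogen would do as well. On these data alone, it also remains open whether the same swap of fluoro for cyano would read the same way on a different core, or on an amide ring that carries further groups.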